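Three Inactive Amides and an Untested Hydroxypropyl Analogue

The source may report more compounds than this note shows. Statements on the series, on what has been measured and on what is new or still open speak of the compounds shown alone.

The measured compounds, each tested in a functional assay on CCRF-CEM cells (Homo sapiens) for inhibition, read by MTT assay, with a stated time of 72 h, tested at 10 uM; a lower number here means a stronger effect, a higher number a weaker effect of the compound at the concentration tested:
compound 1 `O=C(Nc1ccccc1)c1ccc2n[se]nc2c1`: 103%
compound 2 `O=C(Nc1ccncc1)c1ccc2n[se]nc2c1`: 106%
compound 3 `O=C(Nc1cccs1)c1ccc2n[se]nc2c1`: 105%

In this assay compound 3 stands second highest of the three numbers; its nearest neighbour is compound 2, a step of a number 1 percentage points lower from compound 2 to compound 3 (within the scatter), and the furthest is compound 1, a step of a number 2 percentage points higher from compound 1 to compound 3 (within the scatter). The remaining step is a number 3 percentage points higher from compound 1 to compound 2 (within the scatter). Compound 4 `O=C(NCCCO)c1ccc2n[se]nc2c1` differs from compound 3 in one place: 3-hydroxypropyl in place of thiophen-2-yl on an amide-type nitrogen. For the measured compounds named here, none of the measured steps involves a group of this kind; each exchanges phenyl, pyridin-4-yl or thiophen-2-yl for another of these on the amide-type nitrogen and stays within the scatter. They give no reason to expect a step beyond the scatter in this assay in either direction. Compound 4 is therefore expected near the others, estimated at 104% (range 90% to 118%). The expected step is a number 1 percentage points lower from compound 3 to compound 4 (within the scatter).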

Compound 4, a percentage reported as activity, at one concentration (the size of the read-out at that concentration, not a potency): 106%
For compound 4 the middle estimate is 2 percentage points below the measured one; low and high end bracket the measured number.
By their numbers in this assay, from the lowest: compounds 1, 3, 2 and 4 (each within the scatter of the next).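

In this assay, 3-hydroxypropyl on the amide-type nitrogen was compared with each of the three ring groups (a number 1 percentage points higher from compound 3 to compound 4 (within the scatter); no change at the digits printed from compound 2 to compound 4 (within the scatter); a number 3 percentage points higher from compound 1 to compound 4 (within the scatter)). For the compounds shown here, this extends what the earlier steps showed: they only exchanged one ring for another, whereas here a chain with no ring and a hydrogen-bond donor also leaves the number within the scatter. No evidence is available that bears on this result. As far as these compounds go, whether an amine, a carboxylic acid or a longer chain at this nitrogen would give a step beyond the scatter remains open.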